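The compounds below may be only part of what the source reports. "The series", "measured", "known", "first", "only" and "open" are said of these compounds alone.

Values in an in vitro ADME assay on microsomes from liver (Homo sapiens) for pharmacokinetics, read by LC-MS, with a stated time of 10 min, tested at 1 uM; a lower number here means slower removal, a higher number faster removal of the compound:
- compound 1 `CN1C[C@H](C(=O)Nc2ccc(C#N)cc2)[C@@H](c2ccc(/C=C/C(=O)Nc3ccccc3N)cc2)C1`: 1 mL/min/kg
- compound 2 `Cc1cc(NC(=O)[C@H]2CN(C)C[C@@H]2c2ccc(/C=C/C(=O)Nc3ccccc3N)cc2)ccc1F`: 15 mL/min/kg
- compound 3 `CN1C[C@H](C(=O)Nc2cccnc2)[C@@H](c2ccc(/C=C/C(=O)Nc3ccccc3N)cc2)C1`: 10 mL/min/kg

Two steps fix where the last of these stands: a 1.5-fold lower number from compound 2 to compound 3 (0.18 log units; within the scatter), level with its neighbour, and a 10-fold higher number from compound 1 to compound 3 (1.00 log units; beyond the scatter), well clear of the lowest value.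

Compound 4 `CN1C[C@H](C(=O)NC2CCCC2)[C@@H](c2ccc(/C=C/C(=O)Nc3ccccc3N)cc2)C1` carries cyclopentyl in place of pyridin-3-yl on an amide-type nitrogen. Going by the values given here, no measured compound has a non-aromatic ring at this place, so the measured steps bear on the change only indirectly. The largest, a 15-fold higher number from compound 1 to compound 2 (1.18 log units; beyond the scatter), shows that exchanges here can move the number far, which keeps the range wide. The expected step, slightly upward and not beyond the scatter, is a 1.4-fold higher number from compound 3 to compound 4 (0.15 log units; within the scatter). Compound 4 is estimated at 14 mL/min/kg, with an expected range of 5 mL/min/kg to 40 mL/min/kg.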

Compound 4, clearance: 9 mL/min/kg
For compound 4 the middle estimate is 1.6-fold (0.19 log units) above the measured one, and the stated range covers the measured number.
By their numbers in this assay, from the lowest: compound 1; then compounds 4, 3 and 2 (each within the scatter of the next).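

In this assay, the first non-aromatic ring on the amide-type nitrogen does not separate from the aromatic rings of the neighbouring compounds (a 1.1-fold lower number from compound 3 to compound 4 (0.05 log units; within the scatter); a 1.7-fold lower number from compound 2 to compound 4 (0.22 log units; within the scatter)). Cyclopentyl also stands well clear of 4-cyanophenyl (a 9.0-fold higher number from compound 1 to compound 4 (0.95 log units; beyond the scatter)), so among these four compounds, only compound 1 holds the low number. No measurement here offers an explanation for this pattern.

Still open, going by these compounds, is whether a nitrile on the cyclopentyl ring would bring the number close to that of compound 1. On these data alone, the effect of an open butyl chain or a carboxylic acid at this place also remains unknown.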